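Trading the carbamate chain for a methoxymethyl group

This account rests on a few compounds, and the source may have more. Where it says the series, first, only, none or still open, it means among the compounds named here.

Measured compounds:
compound 1, `CC1=C(N2CC2)C(=O)C(CC(C)OC(N)=O)=C(N2CC2)C1=O`, 5.79
compound 2, `CC1=C(N2CC2)C(=O)C(Cc2ccccc2)=C(N2CC2)C1=O`, 4.69
compound 3, `CCOC(COC(N)=O)C1=C(N2CC2)C(=O)C(C)=C(N2CC2)C1=O`, 5.22

All three share one core and were tested in a functional assay on L1210 cells (Mus musculus), with a stated time of 12 days; a lower number here means a less potent compound, a higher number a more potent compound, by a factor of ten per unit of this negative logarithm. Among these three numbers compound 1 stands highest; compound 3 is nearest to it and compound 2 furthest, and both of those gaps are beyond the usual scatter.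

Compound 4, `COCCC1=C(N2CC2)C(=O)C(C)=C(N2CC2)C1=O`, is not yet measured. It differs from compound 1 in one place: a group of 3 heavy atoms (2 carbon, 1 oxygen; no ring) in place of a group of 6 heavy atoms (3 carbon, 1 nitrogen, 2 oxygen; no ring), on a saturated chain carbon bound to a double-bonded ring carbon

Going by the values given here, one measured step bears directly on this change: a number 1.10 log units lower from compound 1 to compound 2 (beyond the scatter). There the same group of 6 heavy atoms left the same saturated chain carbon, and the number fell by a large amount. Among the compounds with values here, compound 3 keeps the carbamate but on a different chain, and its value sits below that of compound 1; no single-place step connects them, so it only shows that rearranging this part of the molecule matters.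

Because a number 1.10 log units lower from compound 1 to compound 2 (beyond the scatter) was a large loss when this group was removed, a drop is also expected for compound 4, though the entering methoxymethyl is not a ring, so a somewhat smaller fall is estimated: a number 0.89 log units lower from compound 1 to compound 4 (beyond the scatter). The expected value for compound 4 is 4.9, within a range from 4.3 to 5.5.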

Compound 4, logarithm of the reciprocal of the active concentration, log(1/C): 5.42
Estimate against measurement, compound 4: 0.52 log units below; low and high end bracket the measured number.
By their numbers in this assay, from the lowest: compound 2; then compounds 3 and 4 (each within the scatter of the next); then compound 1.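

In this assay, the carbamate chain on this saturated chain carbon turns out not to be essential for activity: with methoxymethyl, a group of 3 heavy atoms, in its place, the change is a number 0.37 log units lower from compound 1 to compound 4 (beyond the scatter), a modest loss and well short of the large fall seen with phenyl. Phenyl and methoxymethyl can also now be compared directly, with a number 0.73 log units higher from compound 2 to compound 4 (beyond the scatter), so the size of the loss depends on which group enters and not only on the carbamate chain leaving. No measurement shown here accounts for this order of phenyl, methoxymethyl and the carbamate chain.

From the compounds shown here alone, each of these swaps replaces a whole group at once, so it remains open which part of the carbamate chain holds the extra activity of compound 1. A hydroxyl group, an amine or a longer ether chain on the same carbon would help to show whether the oxygen of methoxymethyl matters, or whether the terminal amide hydrogens of the carbamate are what counts.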